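The compounds below may be only part of what the source reports. "The series", "measured", "known", "first", "only" and "open" are said of these compounds alone.

Values in a functional assay on HeLa cells (Homo sapiens) for inhibition, read by MTT assay, with a stated time of 48 h; a lower number here means a stronger inhibitor of growth, a higher number a weaker inhibitor of growth:

- Compound 1 `Cc1ccc(C(=O)N2N=C(c3ccccc3)CC2c2cn(C)c3ccccc23)cn1`: 2390 nM
- Compound 2 `Cn1cc(C2CC(c3ccc(Cl)cc3)=NN2C(=O)c2cccnc2)c2cc(Br)ccc21`: 5200 nM

Compound 2, at 5200 nM, has the higher of the two numbers and is the weaker growth inhibitor. Compound 1 reads 2390 nM, and this gap lies beyond the scatter. The two compounds differ in more than one place, so their gap cannot be tied to any single change.

Next in line is compound 3 `COc1ccc(C2=NN(C(=O)c3cccnc3)C(c3cn(C)c4ccc(Br)cc34)C2)cc1`, which departs from compound 2 at one place: methoxy in place of chloro on an aromatic carbon. This puts methoxy in place of chloro on an aromatic carbon, para to a large group, turning 4-chlorophenyl into 4-methoxyphenyl.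

Within the data shown here, no measured step isolates this change, so the expectation stays close to compound 2 at 5200 nM, with a wide margin. The expected change in this assay is small, an estimated 1.2-fold lower number from compound 2 to compound 3 (0.06 log units; within the scatter), and is not expected to exceed the scatter. For compound 3 the estimated value is 4500 nM, with an expected range of 1800 nM to 11000 nM.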

Compound 3, concentration for 50% growth inhibition: 890 nM
Compound 3: middle estimate off by 5.1-fold (0.70 log units), on the high side; the whole stated range lies above it.
By their numbers in this assay, from the lowest: compound 3; then compound 1; then compound 2.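

In this assay, among these compounds, the change from 4-chlorophenyl to 4-methoxyphenyl gives a 5.8-fold lower number from compound 2 to compound 3 (0.77 log units; beyond the scatter), the first step that can be tied to a single place. This shows that the group on this aromatic carbon, para to a large group, is not a silent position on the core of compound 2: with everything else held constant, replacing chloro with methoxy is enough to move growth inhibition beyond the scatter, and compound 3 reaches 890 nM. No measurement on these compounds gives a reason for the step, so it stands as an observation on one pair.

From the compounds shown here alone, a single pair cannot separate what leaving chloro contributes from what entering methoxy contributes, and it gives no trend across groups at this place, so ethoxy, with its longer chain on the same oxygen, as well as a hydroxyl or a dimethylamino group, remain open comparisons. Also open, going by these compounds, is whether the same change would give a step of similar size on the core of compound 1, which carries an unsubstituted phenyl.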